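A few compounds are considered here, and "the series" means these few. Any claim that something is new, unique, unknown or untested is made for them only; others in the source may bear on it.

Measured in a functional assay on U-87MG ATCC cells for antiproliferative activity against U-87 MG (Homo sapiens), read by MTT assay, with a stated time of 48 h, tested at 50 uM; a lower number here means a stronger effect, a higher number a weaker effect of the compound at the concentration tested:

compound 1 `COc1ccc(-c2nc(SCC(=O)c3sc(-c4ccccc4)nc3C)nc(N)c2C#N)cc1` — 33.8%
compound 2 `COc1cccc(-c2nc(SCC(=O)c3sc(-c4ccccc4)nc3C)[nH]c(=O)c2C#N)c1` — 80.3%
compound 3 `COc1ccc(-c2nc(C)c(C(=O)CSc3nc(N)c(C#N)c(-c4ccc(OC)cc4)n3)s2)cc1` — 13%

Compound 2 stands highest of the three numbers, beyond the scatter from both others; compound 1 and compound 3 both give lower numbers, compound 3 lowest. Compound 4 `COc1ccc(-c2nc(SCC(=O)c3sc(-c4ccccc4)nc3C)[nH]c(=O)c2C#N)cc1OC` differs from compound 2 by methoxy in place of hydrogen on an aromatic carbon, so that the change reads 3-methoxyphenyl to 3,4-dimethoxyphenyl. For the measured compounds named here, the one measured step of the same kind, methoxy in place of hydrogen on an aromatic carbon, is a number 20.8 percentage points lower from compound 1 to compound 3 (beyond the scatter), though there the group enters a different ring of the shared core. A step in the same direction, of similar or somewhat smaller size, is expected in this assay: a number 16.3 percentage points lower from compound 2 to compound 4 (beyond the scatter). Compound 4 is thus estimated at 64%, within 45% to 83%.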

Compound 4, a percentage reported as activity, at one concentration (the size of the read-out at that concentration, not a potency): 21.4%
Estimate against measurement, compound 4: 42.6 percentage points above; measured number below the stated range.
By their numbers in this assay, from the lowest: compounds 3 and 4 (each within the scatter of the next); then compound 1; then compound 2.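

In this assay, the change from 3-methoxyphenyl to 3,4-dimethoxyphenyl gives a number 58.9 percentage points lower from compound 2 to compound 4 (beyond the scatter), a large step for a methoxy entering ortho to a methoxy group and para to a large group. The same change does not keep one size in this series, although the two steps also differ in the ring that receives the methoxy: the same change on two cores in this assay, a number 20.8 percentage points lower (beyond the scatter) from compound 1 to compound 3 and a number 58.9 percentage points lower (beyond the scatter) from compound 2 to compound 4, 38.1 percentage points apart, beyond the scatter of two such steps

Open, from the compounds shown here alone, is whether a hydroxy group, a fluorine or an ethoxy group at this position would give a step of similar size. Also open, going by these compounds, is how 3,4-dimethoxyphenyl would read on the core of compound 1.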